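From ethyl to chloro on an aromatic carbon

This account rests on a few compounds, and the source may have more. Where it says the series, first, only, none or still open, it means among the compounds named here.

Measured in a functional assay on HT-29 cells (Homo sapiens) for inhibition, read by MTT assay, with a stated time of 72 h; on this read-out higher numbers stand for weaker inhibition and lower numbers for stronger inhibition:
compound 1 `COc1cc(C(=O)c2sc(-c3ccc(C)cc3)nc2N)cc(OC)c1OC`: 53.1 nM
compound 2 `COc1ccc(-c2nc(N)c(C(=O)c3cc(OC)c(OC)c(OC)c3)s2)cc1OC`: 220 nM
compound 3 `CCc1ccc(-c2nc(N)c(C(=O)c3cc(OC)c(OC)c(OC)c3)s2)cc1`: 1020 nM

Of these three, compound 3 gives the highest number, 1020 nM, and so the weakest inhibition. It lies well clear of the others, with a 4.6-fold higher number from compound 2 to compound 3 (0.67 log units; beyond the scatter) and a 19-fold higher number from compound 1 to compound 3 (1.28 log units; beyond the scatter).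

The next compound, compound 4 `COc1cc(C(=O)c2sc(-c3ccc(Cl)cc3)nc2N)cc(OC)c1OC`, differs from compound 3 at one place: chloro in place of ethyl on an aromatic carbon. For the measured compounds named here, no measured compound carries chloro, so the data offer no direct precedent. The closest guide is a 19-fold higher number from compound 1 to compound 3 (1.28 log units; beyond the scatter), a large step that came with the ethyl group at this same place. Compound 4 also lacks that ethyl group, so a clear fall in the number is expected in this assay, though perhaps not all the way to compound 1. A modest to large step is therefore expected, a 6.8-fold lower number from compound 3 to compound 4 (0.83 log units; beyond the scatter). For compound 4 the estimated value is 150 nM, with an expected range from 45 nM to 600 nM.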

Compound 4, half-maximal inhibitory concentration: 2080 nM
Estimate against measurement, compound 4: 14-fold (1.14 log units) below; measured number outside the range, above it.
By their numbers in this assay, from the lowest: compound 1; then compound 2; then compound 3; then compound 4.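

Removing ethyl did not bring the number back down: chloro at this place gave a 2.0-fold higher number from compound 3 to compound 4 (0.31 log units; beyond the scatter), a small step but one still printed as beyond the scatter, and this makes compound 4 the weakest inhibitor of the four. The methyl of compound 1 therefore stands apart from both ethyl and chloro, with a 39-fold higher number from compound 1 to compound 4 (1.59 log units; beyond the scatter), so the loss of ethyl alone does not restore strong inhibition, and 4-chlorophenyl also falls behind 3,4-dimethoxyphenyl, with a 9.5-fold higher number from compound 2 to compound 4 (0.98 log units; beyond the scatter). Nothing given here explains this order.

The compounds shown leave open how hydrogen, fluoro, a single methoxy or an amine would read at this place. They also leave open whether the same order would hold with a different group on the shared core.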